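Ester Change on a Dihydropyrimidinone Core: Benzyl to Cyclopropylmethyl

A few compounds are considered here, and "the series" means these few. Any claim that something is new, unique, unknown or untested is made for them only; others in the source may bear on it.

Measured compounds:
compound 1, `CC1=C(C(=O)OCc2ccccc2)C(c2ccco2)NC(=O)N1`, 3%
compound 2, `CC1=C(C(=O)OCc2ccccc2)C(c2ccsc2)NC(=O)N1`, 25%
compound 3, `CC1=C(C(=O)OCc2ccccc2)C(c2ccco2)NC(=O)N1C`, 11%

In an assay on membranes from HeLa cells for displacement of a labelled ligand from adenosine receptor A3 (Homo sapiens), read by scintillation counting, with a stated time of 180 min, tested at 1 uM (on this read-out higher numbers stand for more inhibition at the one concentration tested (going by the name of the read-out) and lower numbers for less inhibition), compound 1 gives 3%, the lowest of the three numbers. Compound 3 stands nearest, with a number 8 percentage points higher from compound 1 to compound 3 (within the scatter); compound 2 stands furthest, with a number 22 percentage points higher from compound 1 to compound 2 (beyond the scatter).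

Compound 4, `CC1=C(C(=O)OCC2CC2)C(c2ccco2)NC(=O)N1`, differs from compound 1 in the ester group only: cyclopropyl in place of phenyl on a saturated chain carbon bound to an oxygen next to a carbonyl group. Neither measured step touches that part of the shared core. Among the compounds with values here, the step from compound 1 to compound 2 concerns the group on a saturated ring carbon, and the step from compound 1 to compound 3 concerns the amide-type nitrogen in the ring, so no measured step bears on this change. With nothing to carry the change in either direction, compound 4 is expected to stay near compound 1, and the estimated step is a number 2 percentage points higher from compound 1 to compound 4 (within the scatter), not beyond the scatter. The estimate for compound 4 in this assay is therefore 5%, with a range from -5% to 18%.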

Compound 4, a percentage reported as inhibition, at one concentration (the size of the read-out at that concentration, not a potency): 1%
For compound 4 the middle estimate is 4 percentage points above the measured one; low and high end bracket the measured number.
By their numbers in this assay, from the lowest: compounds 4, 1 and 3 (each within the scatter of the next); then compound 2.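

In this assay, cyclopropyl in place of phenyl on a saturated chain carbon bound to an oxygen next to a carbonyl group gives a number 2 percentage points lower from compound 1 to compound 4 (within the scatter), the only reading at this place among the compounds shown. The swap from benzyl to cyclopropylmethyl, which replaces an aromatic ring with a three-membered non-aromatic ring, therefore leaves no step beyond the scatter, but with compound 1 at 3% and compound 4 at 1%, both numbers are small and a further loss would be hard to see. No evidence on the reason for this result is available.

As far as these compounds go, it remains open whether the same change would hold on compound 2, which gives the higher 25% in this assay. Also open, from the compounds shown here alone, is how an amine, a carboxylic acid or a longer chain at this place would read.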